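The compounds below may be only part of what the source reports. "The series", "measured", "known", "first", "only" and "open" are said of these compounds alone.

Compounds measured so far in a physicochemical assay for lipophilicity, at pH 7.4; on this read-out higher numbers stand for higher lipophilicity and lower numbers for lower lipophilicity:
- compound 1, `Cc1cc(COc2ccc(F)cc2F)nc(-c2ccccn2)n1`, gives 3.1
- compound 2, `Cc1cc(COc2cc(F)c(F)cc2F)nc(-c2ccccn2)n1`, gives 3.2
- compound 3, `OC1CN(c2cc(COc3ccc(F)c(F)c3F)nc(-c3ccccn3)n2)C1`, gives 2.8

Among these three numbers, compound 3 sits close to compound 1, a gap within the usual scatter, and only its gap to compound 2 goes beyond the scatter. So compound 3 is not clearly apart from compound 1, but it is clearly below compound 2.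

Compound 4, `Fc1ccc(OCc2cc(OCC3(F)COC3)nc(-c3ccccn3)n2)c(F)c1F`, has not been measured yet. It differs from compound 3 in one place: (3-fluorooxetan-3-yl)methoxy in place of 3-hydroxyazetidin-1-yl on an aromatic carbon. The group that leaves carries a hydroxyl donor; the group that enters carries no donor but a fluorine.

Within the data shown here, only one measured step exists, a number 0.10 log units higher from compound 1 to compound 2 (within the scatter), and it concerns a fluorine added to the aromatic ring, not an exchange of a whole four-membered ring group. It therefore gives little direct guidance. With the donor gone and a fluorine and an extra carbon coming in, the number is expected to move upward, with a step of about a number 0.40 log units higher from compound 3 to compound 4 (beyond the scatter) expected in this assay. Compound 4 is estimated at 3.2, within a range from 2.7 to 3.7.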

Compound 4, distribution coefficient: 4
Estimate against measurement, compound 4: 0.80 log units below, outside the stated range (above it).
By their numbers in this assay, from the lowest: compounds 3, 1 and 2 (each within the scatter of the next, the first and the last beyond it); then compound 4.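

Among these compounds, exchanging 3-hydroxyazetidin-1-yl for (3-fluorooxetan-3-yl)methoxy on this aromatic carbon gives a number 1.20 log units higher from compound 3 to compound 4 (beyond the scatter) in this assay, a large step, whereas the only earlier step, a number 0.10 log units higher from compound 1 to compound 2 (within the scatter), a fluoro in place of a hydrogen, stayed inside the scatter. So a change at this position, opposite the ring nitrogen, can move the read-out well beyond the scatter, something the earlier compounds did not show. Several things differ at once, though: the entering group has 7 heavy atoms against 5 and 0 hydrogen-bond donors against 1, it carries a fluorine, and it is attached through oxygen rather than the ring nitrogen, and nothing available here accounts for the size of the step.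

The compounds shown leave open which of these differences carries the step, as a single exchange cannot separate them. A compound with (oxetan-3-yl)methoxy at this position, lacking only the fluorine, would isolate that atom's share, and a 3-methoxyazetidin-1-yl group would do the same for the hydroxyl hydrogen while keeping the four-membered ring in place.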